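Adding a fluoro to compound 3

This account rests on a few compounds, and the source may have more. Where it says the series, first, only, none or still open, it means among the compounds named here.

In a functional assay on HCT-116 cells (Homo sapiens) for inhibition, read by MTT assay, with a stated time of 72 h (on this read-out higher numbers stand for weaker inhibition and lower numbers for stronger inhibition), compound 3 `Nc1ccccc1NC(=O)c1ccc(CNC(=O)/C=C/c2cnc3cccnn23)cc1` gives 1260 nM and stands level with compound 1 `Nc1ccccc1NC(=O)c1ccc(CNC(=O)/C=C/c2c[nH]c3ccccc23)cc1` at 1220 nM as the step of a 1.0-fold higher number from compound 1 to compound 3 (0.01 log units; within the scatter) shows. Compound 2 `Nc1ccc(F)cc1NC(=O)c1ccc(CNC(=O)/C=C/c2cnc3cccnn23)cc1` at 4290 nM lies clearly higher than both. Compound 4 `Nc1cc(F)ccc1NC(=O)c1ccc(CNC(=O)/C=C/c2cnc3cccnn23)cc1` is compound 3 with fluoro in place of hydrogen on an aromatic carbon, meta to an amino group and para to a large group (fluoro in place of hydrogen on an aromatic carbon). Going by the values given here, the one step that bears on this is a 3.4-fold lower number from compound 2 to compound 3 (0.53 log units; beyond the scatter) in which hydrogen replaces a fluoro on a different carbon of that ring. A rise in this assay is therefore expected, but a smaller one that may stay within the scatter. The expected change is a 1.4-fold higher number from compound 3 to compound 4 (0.15 log units; within the scatter) and no larger. Compound 4 is estimated at 1800 nM with an expected range from 700 nM to 4500 nM on this reasoning.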

Compound 4, half-maximal inhibitory concentration: 2260 nM
For compound 4 the middle estimate is 1.3-fold (0.10 log units) below the measured one; the range from low to high includes it.
By their numbers in this assay, from the lowest: compounds 1, 3, 4 and 2 (each within the scatter of the next, the first and the last beyond it).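

In this assay fluoro on this carbon, meta to an amino group and para to a large group, gives a 1.8-fold higher number from compound 3 to compound 4 (0.25 log units; within the scatter) and so cannot be told apart from hydrogen. The shift from 2-amino-5-fluorophenyl to 2-amino-4-fluorophenyl gives a 1.9-fold lower number from compound 2 to compound 4 (0.28 log units; within the scatter), which places compound 4 within the scatter of both compound 2 and compound 3, although those two lie beyond it. Nothing given here explains these numbers. Still open, going by these compounds, is how chloro or methoxy would read on this carbon, and whether this fluoro would read alike on the core of compound 1.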